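Restoring the Acid while Methylating the Amide Nitrogen

The source may report more compounds than this note shows. Statements on the series, on what has been measured and on what is new or still open speak of the compounds shown alone.

Measured in an assay on isolated protein for inhibition of endoplasmic reticulum aminopeptidase 1 (Homo sapiens), with stated times of 15 min and 20 min; a higher number here means a weaker inhibitor, a lower number a stronger inhibitor:
compound 1, `CCC(C)(NC(=O)c1cc(F)cc2cc(-c3ccc(C(F)(F)F)cc3)oc12)C(=O)O`: 2680 nM
compound 2, `CC(C)(NC(=O)c1cc(F)cc2cc(-c3ccc(Cl)cc3)oc12)C(N)=O`: > 10000 nM
compound 3, `O=C(NC1(C(=O)O)Cc2ccccc2C1)c1cc(F)cc2cc(-c3ccc(Cl)cc3)oc12`: 115 nM

The three compounds share one core and differ only in the group attached to the carbonyl carbon. Compound 3 carries a ring-fused acid and gives 115 nM, the strongest result among the three. Compound 1 carries an open-chain acid with a different aryl substituent and gives 2680 nM. Compound 2, which carries a primary amide in place of an acid, reaches only a limit of this assay: > 10000 nM. That limit is the limit of > 10000 nM in this assay, at which 1 of the 3 values shown sits, so compound 2 stands at the weak end of what was measured, with no exact number.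

Compound 4, `CN(C(=O)c1cc(F)cc2cc(-c3ccc(Cl)cc3)oc12)C(C)(C)C(=O)O`, is not yet measured. It differs from compound 2 by (1-carboxy-1-methylethyl)(methyl)amino in place of (1-carbamoyl-1-methylethyl)amino on a carbonyl carbon. Among the measured compounds shown here, the acid returns, as in compound 1 and compound 3, while the amide nitrogen now carries a methyl group, something none of the measured compounds has. Since compound 2 is known only as a limit, the step cannot be fixed precisely. The acid-bearing compound 1 at 2680 nM suggests that regaining the acid should move the number down. The step from compound 2 to compound 4 is therefore expected to be an improvement, an at least 3.3-fold lower number from compound 2 to compound 4 (0.52 log units; beyond the scatter). Compound 4 is estimated to give 3000 nM, within a range from 800 nM to 10000 nM.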

Compound 4, half-maximal inhibitory concentration: 1970 nM
For compound 4 the middle estimate is 1.5-fold (0.18 log units) above the measured one; measured number inside the range.
By their numbers in this assay, from the lowest: compound 3; then compounds 4 and 1 (each within the scatter of the next). At a limit, above all of these: compound 2.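

In this assay the new group on the carbonyl carbon brings an at least 5.0-fold lower number from compound 2 to compound 4 (0.70 log units; beyond the scatter) and turns a compound without an exact number into one with a measured value. Among the compounds shown here, compound 4 carries a methyl group on the amide nitrogen in place of the amide hydrogen found in the earlier compounds, so this result is the first to show that a readable value can be obtained without that hydrogen, at least when a carboxylic acid is also present. Going by these compounds, the real size of the step remains open-ended, since compound 2 is known only as a limit: the limit of > 10000 nM in this assay, at which 1 of the 4 values shown sits.

The step replaces the carbamoyl group with a carboxy group and adds the methyl group at the same time, so the compounds shown cannot tell how much of the change belongs to each part. They also leave open how an ethyl group on the amide nitrogen, or a tetrazole in place of the carboxylic acid, would behave in this assay on this same core.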